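A few compounds are considered here, and "the series" means these few. Any claim that something is new, unique, unknown or untested is made for them only; others in the source may bear on it.

Measured in a functional assay on A549 cells (Homo sapiens) for cytotoxicity, read by MTT assay, with a stated time of 72 h; a higher number here means a weaker inhibitor, a lower number a stronger inhibitor:
- Compound 1 `COc1cccc(/C=C2\CCC/C(=C\c3ccc(Cl)cc3)C2=O)c1OC` gives > 20000 nM, which is a limit.
- Compound 2 `COc1cccc(/C=C2\CCC/C(=C\c3ccc(Cl)c(Cl)c3)C2=O)c1OC` gives > 20000 nM, which is a limit.
- Compound 3 `COc1ccc(/C=C2\CCC/C(=C\c3cccc(Cl)c3)C2=O)cc1OC` gives 11000 nM.

Going by the values given here, compound 3 holds the only true number in this small set, at 11000 nM. The other two compounds sit at a limit, as the limit of > 20000 nM in this assay, at which 2 of the 3 values shown sit, shows. Compound 4 `COc1ccc(/C=C2\CCC/C(=C\c3ccccc3Br)C2=O)cc1OC` carries 2-bromophenyl in place of 3-chlorophenyl on a double-bonded chain carbon bound to a double-bonded ring carbon. Among the compounds with values here, the only measured step, a step that the two limits leave unreadable from compound 1 to compound 2, offers no size to carry over, and no measured step covers this exchange. The expectation therefore rests on compound 3 at 11000 nM, with no clear direction in this assay. The expected change is a 1.2-fold higher number from compound 3 to compound 4 (0.07 log units; within the scatter), which is no step beyond the scatter. The estimated value for compound 4 is 13000 nM, with an expected range from 5500 nM to 30000 nM.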

Compound 4, half-maximal inhibitory concentration: > 20000 nM
Compound 4 was reported as a limit; the forecaster's own chance of this, stated with the estimate: 35%; middle value at least 1.5-fold (0.18 log units) away from the limit.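

In this assay compound 4 gives > 20000 nM, which is a limit. As far as these compounds go, the exchange of 3-chlorophenyl for 2-bromophenyl on a double-bonded chain carbon bound to a double-bonded ring carbon gives an at least 1.8-fold higher number from compound 3 to compound 4 (0.25 log units; that floor lies within the scatter), so this change brings no stronger inhibition, while the true size of the step remains unknown. Most of the set now rests at one ceiling: the limit of > 20000 nM in this assay, at which 3 of the 4 values shown sit.

From the compounds shown here alone, whether the step truly exceeds the scatter stays open. So does how a dimethylamino group or a carboxylic acid on the phenyl ring at this position would read.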